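Working notes: compound 3 to compound 4 in the series

The source may hold more compounds than are shown below. What is called first, only, known or untested is meant among the compounds shown, and "the series" means these compounds.

Measured so far:
compound 1, `COCN(c1ccc2c(c1)S(=O)(=O)N=C(c1c(O)c(-c3cccs3)nn(CCC(C)C)c1=O)N2)S(C)(=O)=O`; in an in vitro ADME assay on microsomes from liver (Homo sapiens) for metabolic stability, tested at 5 uM (a lower number here means that the compound disappears faster, a higher number that the compound lasts longer), compound 1 gives 0.183 h
compound 2, `CC(C)CCn1nc(-c2cccs2)c(O)c(C2=NS(=O)(=O)c3cc(S(C)(=O)=O)ccc3N2)c1=O`; in this assay compound 2 gives 0.0933 h
compound 3, `CC(C)CCn1nc(-c2ccn(C)c2)c(O)c(C2=NS(=O)(=O)c3cc(NS(C)(=O)=O)ccc3N2)c1=O`; in this assay compound 3 gives 0.633 h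

Compound 3 stands highest of the three numbers in this assay; its gaps to compound 1 and to compound 2 are both beyond the scatter. Compound 4, `C/C(=C\c1nn(CCC(C)C)c(=O)c(C2=NS(=O)(=O)c3cc(NS(C)(=O)=O)ccc3N2)c1O)C(F)(F)F`, differs from compound 3 in one place: 2-(trifluoromethyl)prop-1-en-1-yl in place of 1-methyl-1H-pyrrol-3-yl on an aromatic carbon.

Among the compounds with values here, the only measured step, a 2.0-fold lower number from compound 1 to compound 2 (0.29 log units; within the scatter), concerns a different aromatic carbon and a different pair of groups, so it does not bear on this change. Within the data shown here, no measured pair in the set varies the group at the aromatic carbon where the change sits, and the two other compounds carry a thiophenyl group there rather than the groups involved here. Among the measured compounds shown here, with no precedent, no step beyond the scatter is expected in this assay in either direction; a modest downward move is left open within the range.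

For compound 4 the half-life in this assay is expected at 0.5 h, with a range of 0.2 h to 1.3 h. This estimate means a step of a 1.3-fold lower number from compound 3 to compound 4 (0.10 log units; within the scatter), which is expected to stay within the scatter.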

Compound 4, half-life: 0.167 h
The estimate for compound 4 lay 3.0-fold (0.48 log units) above the measured number; measured number outside the range, below it.
By their numbers in this assay, from the lowest: compounds 2, 4 and 1 (each within the scatter of the next); then compound 3.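

In this assay, within the data shown here, replacing 1-methyl-1H-pyrrol-3-yl with 2-(trifluoromethyl)prop-1-en-1-yl on the aromatic carbon ortho to a hydroxy group gives a 3.8-fold lower number from compound 3 to compound 4 (0.58 log units; beyond the scatter), the first measured step at this position. Among these compounds, the half-life therefore responds to the group on this carbon when the rest of compound 3 is held constant, whereas the only other step, a 2.0-fold lower number from compound 1 to compound 2 (0.29 log units; within the scatter), sits at a different aromatic carbon. Nothing measured here accounts for this step.

The compounds shown do not separate the loss of the five-membered aromatic ring from the entry of the trifluoromethyl group or of the double bond outside aromatic rings. As far as these compounds go, how a saturated propyl chain, a phenyl ring or an amine on this carbon would stand in this assay remains open.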